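Pyridin-3-yl for Methoxyphenyl on an Amide Carbonyl

The compounds below may be only part of what the source reports. "The series", "measured", "known", "first", "only" and "open" are said of these compounds alone.

Compound 1 `Cc1cc(C)c2cc(C#N)c(N3CCN(C(=O)c4ccccn4)CC3)nc2c1` and compound 2 `COc1cccc(C(=O)NCCCNc2nc3cc(C)cc(C)c3cc2C#N)c1` were both examined in an in vitro assay on FRT cells with Cystic fibrosis transmembrane conductance regulator variant F508del (Homo sapiens) as the target, read by fluorescence, with a stated time of 24 h, at 37 degrees C, in the presence of a further agent that is not named here; on this read-out lower numbers stand for an effect already at smaller amounts and higher numbers for an effect only at larger amounts of compound. Compound 1 was recorded as "not active" (no number reported) in this assay, with no number given. Compound 2 gave 4600 nM in this assay. Within the data shown here, since this is the only number among the compounds described, and the further entry carries no number, compound 2 stands alone: it can be ranked neither above nor below any other measured compound.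

Compound 3 `Cc1cc(C)c2cc(C#N)c(NCCCNC(=O)c3cccnc3)nc2c1` has not yet been measured. It differs from compound 2 in a single place: pyridin-3-yl in place of 3-methoxyphenyl on a carbonyl carbon. Among the measured compounds shown here, no step between two measured compounds is on record that would show how such a swap plays out, so any expectation rests on compound 2 alone and on the modest size of the change.

The step from compound 2 to compound 3 is expected to be small, a 1.3-fold higher number from compound 2 to compound 3 (0.12 log units; within the scatter), lying within the usual scatter of this kind of measurement rather than beyond it. In this assay compound 3 is therefore estimated at 6000 nM, with a range from 2000 nM to 20000 nM.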

Compound 3, half-maximal effective concentration: 3000 nM
Compound 3: the middle estimate sits 2.0-fold (0.30 log units) above what was measured, within the range that was stated.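

In this assay, among these compounds, pyridin-3-yl in place of 3-methoxyphenyl on a carbonyl carbon gives a 1.5-fold lower number from compound 2 to compound 3 (0.19 log units; within the scatter), the first step on record at this place, and it shows that an all-carbon aromatic ring can give way to one with 1 hetero atom, and the methoxy group can go, without a change that the measurement can separate from its scatter. Among the compounds shown here, compound 2 and compound 3 therefore cannot be ordered, and the series now has two measured values at this place instead of one, though compound 1 differs from both in more than one place, so no step to it can be read. No measured evidence bears on this result, and the data give no account of why the two groups read alike.

For the compounds shown here, only two aromatic groups have been compared here, so the effect of a non-aromatic group on this carbonyl carbon, such as a cyclohexyl ring, or of a carboxylic acid or an amine on the ring, remains open. On these data alone, it also remains open whether pyridin-2-yl or pyridin-4-yl would read like pyridin-3-yl, or whether a longer chain on the amide-type nitrogen would shift the number beyond the scatter.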